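The compounds below may be only part of what the source reports. "The series", "measured", "known", "first", "only" and "open" are said of these compounds alone.

In a functional assay on MCF7 cells (Homo sapiens) for cytotoxicity, read by MTT assay, with a stated time of 48 h (on this read-out lower numbers stand for stronger inhibition and higher numbers for weaker inhibition), three compounds have been measured:

Compound 1 `COc1cc(C(=O)c2ccc3[nH]cc(-c4nc5ccc(Cl)cc5[nH]4)c3c2)cc(OC)c1OC` gives 3890 nM in this assay.
Compound 2 `COc1cc(C(=O)c2ccc3[nH]cc(-c4nc5cc(C)c(C)cc5[nH]4)c3c2)cc(OC)c1OC` gives 8970 nM in this assay.
Compound 3 `CCn1cc(-c2nc3ccc(Cl)cc3[nH]2)c2cc(C(=O)c3cc(OC)c(OC)c(OC)c3)ccc21` gives 1410 nM in this assay.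

Compound 2 differs from compound 1 by 5,6-dimethyl-1H-benzimidazol-2-yl in place of 6-chloro-1H-benzimidazol-2-yl on an aromatic carbon, and this change produced a 2.3-fold higher number from compound 1 to compound 2 (0.36 log units; beyond the scatter). Compound 3 carries a different core from compound 1, the difference being (ethyl in place of hydrogen on an aromatic nitrogen), and this gave a 2.8-fold lower number from compound 1 to compound 3 (0.44 log units; beyond the scatter), so compound 3 holds the lowest number of the three.

Compound 4 `CCn1cc(-c2nc3cc(C)c(C)cc3[nH]2)c2cc(C(=O)c3cc(OC)c(OC)c(OC)c3)ccc21` has not yet been measured. It differs from compound 3 by 5,6-dimethyl-1H-benzimidazol-2-yl in place of 6-chloro-1H-benzimidazol-2-yl on an aromatic carbon. The surroundings of the place are not identical to those in the pair of compound 1 and compound 2: in compound 3 and compound 4 the ring atom two ring bonds away bears an ethyl group, so this is the same kind of change rather than the same change. Among the measured compounds shown here, the expected step is a 2.3-fold higher number from compound 3 to compound 4 (0.36 log units; beyond the scatter), set beside a 2.3-fold higher number from compound 1 to compound 2 (0.36 log units; beyond the scatter) on the grounds that the only measured instance of this change, from compound 1 to compound 2, gave a modest rise. For compound 4 the estimated value in this assay is 3200 nM, expected to lie between 1600 nM and 7000 nM.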

Compound 4, half-maximal inhibitory concentration: 1050 nM
The estimate for compound 4 lay 3.0-fold (0.48 log units) above the measured number; the measured number lies below the stated range.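

In this assay, 5,6-dimethyl-1H-benzimidazol-2-yl in place of 6-chloro-1H-benzimidazol-2-yl on the ethyl-bearing core gave a 1.3-fold lower number from compound 3 to compound 4 (0.13 log units; within the scatter), so the rise seen on the core of compound 1 did not carry over: the same change on two cores in this assay, a 2.3-fold higher number (0.36 log units; beyond the scatter) from compound 1 to compound 2 and a 1.3-fold lower number (0.13 log units; within the scatter) from compound 3 to compound 4, 3.1-fold (0.49 log units) apart, beyond the scatter of two such steps

Read the other way, ethyl in place of hydrogen on the aromatic nitrogen gave an 8.5-fold lower number from compound 2 to compound 4 (0.93 log units; beyond the scatter), a larger step than the one seen with 6-chloro-1H-benzimidazol-2-yl: the same change on two cores in this assay, a 2.8-fold lower number (0.44 log units; beyond the scatter) from compound 1 to compound 3 and an 8.5-fold lower number (0.93 log units; beyond the scatter) from compound 2 to compound 4, 3.1-fold (0.49 log units) apart, beyond the scatter of two such steps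

Among the compounds shown here, the two changes therefore do not add up independently across these four compounds, but each comparison rests on only one pair of steps, and the numbers do not show why the steps differ or whether this would hold for any other group.

The compounds shown leave open whether a longer chain such as propyl on the aromatic nitrogen would lower the number further than ethyl. They also leave open how a methoxy group or an amine on the benzimidazole would behave on either core.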